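A few compounds are considered here, and "the series" means these few. Any claim that something is new, unique, unknown or untested is made for them only; others in the source may bear on it.

Compound 1 `CCCCCCn1cnc2c(Nc3ccc(Cl)cc3)nc(N[C@H]3CC[C@H](N)CC3)nc21` gives 4200 nM
Compound 2 `COc1ccc(Cn2cnc3c(Nc4cccc(Cl)c4)nc(N[C@H]4CC[C@H](N)CC4)nc32)cc1` gives 4800 nM

Both numbers come from a functional assay on MCF7 cells (Homo sapiens) for inhibition, read by fluorescence, with a stated time of 72 h (a lower number here means a stronger inhibitor of growth, a higher number a weaker inhibitor of growth), and lie within the usual scatter of each other, so compound 2 cannot be told apart from compound 1 on this evidence. For the measured compounds named here, no measured pair differs in one place only. Compound 3 `CC(C)CCn1cnc2c(Nc3cccc(Cl)c3)nc(N[C@H]3CC[C@H](N)CC3)nc21` has not been measured yet. Compared with compound 2, it carries isobutyl in place of 4-methoxyphenyl on a saturated chain carbon bound to an aromatic nitrogen and nothing else changes. Compound 1 also holds an open chain, hexyl, at that place and differs elsewhere too, yet compound 1 (at 4200 nM) sits within the scatter of compound 2. No change beyond the scatter is therefore expected in this assay and the estimated 1.2-fold lower number from compound 2 to compound 3 (0.08 log units; within the scatter) is small. For compound 3 the estimated value is 4000 nM in an expected range from 1800 nM to 9000 nM and awaits measurement.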

Compound 3, concentration for 50% growth inhibition: 2100 nM
Compound 3: the middle estimate sits 1.9-fold (0.28 log units) above what was measured; measured number inside the range.
By their numbers in this assay, from the lowest: compounds 3, 1 and 2 (each within the scatter of the next, the first and the last beyond it).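

In this assay, for the compounds shown here, isobutyl in place of 4-methoxyphenyl on a saturated chain carbon bound to an aromatic nitrogen gives a 2.3-fold lower number from compound 2 to compound 3 (0.36 log units; beyond the scatter) and this is the first clean single change in the set, showing that the number responds to what is attached at this place. The aromatic ring and its oxygen are not required for growth inhibition in this assay, since the open chain of compound 3, with fewer heavy atoms, gives the lower number. Nothing measured here accounts for the step.

Still open, going by these compounds, is which part of the change matters: the loss of the ring, the loss of the methoxy group or the branching of the chain. A plain benzyl group, a straight pentyl chain or a chain ending in an amine at this place would help separate these.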